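The compounds below may be only part of what the source reports. "The series", "measured", "known", "first", "only" and "open" are said of these compounds alone.

Measured so far:
- compound 1, `O=C(C1CCCCC1)N1N=CCC1c1ccccc1`: 5.9
- compound 2, `O=C(C1CCOCC1)N1N=CCC1c1ccccc1`: 3.1
- compound 3, `O=C(C1CCC1)N1N=CCC1c1ccccc1`: 4.7

All three share one core and differ only in the ring attached to the carbonyl carbon. In a physicochemical assay for lipophilicity, read by HPLC, measured as chromatographic lipophilicity, at pH 7.4 (on this read-out lower numbers stand for lower lipophilicity and higher numbers for higher lipophilicity), compound 3 stands second highest of the three numbers. Its nearest neighbour is compound 1, where the change is a number 1.20 log units lower from compound 1 to compound 3 (beyond the scatter); its furthest is compound 2, where the change is a number 1.60 log units higher from compound 2 to compound 3 (beyond the scatter).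

Compound 4, `O=C(c1ccncc1)N1N=CCC1c1ccccc1`, is not yet measured. It differs from compound 3 as follows: pyridin-4-yl in place of cyclobutyl on a carbonyl carbon.

Going by the values given here, two measured steps bear on this. The step from a ring of carbon only to a ring with one hetero atom, a number 2.80 log units lower from compound 1 to compound 2 (beyond the scatter), and the step back from such a ring to a carbon-only ring, a number 1.60 log units higher from compound 2 to compound 3 (beyond the scatter), were both large. Among the compounds with values here, compound 4 again brings in a ring with a hetero atom and one hydrogen-bond acceptor, so a step downward beyond the scatter is expected in this assay, though the ring entering here is aromatic and larger than cyclobutyl, which no measured pair covers. The expected step is a number 1.20 log units lower from compound 3 to compound 4 (beyond the scatter). For compound 4 the estimate in this assay is 3.5, with a range from 2.7 to 4.3.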

Compound 4, distribution coefficient: 2.7
Estimate against measurement, compound 4: 0.80 log units above, and the stated range covers the measured number.
By their numbers in this assay, from the lowest: compound 4; then compound 2; then compound 3; then compound 1.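

In this assay, pyridin-4-yl on the carbonyl carbon gives the lowest number of the four compounds, and the change is large against both carbon-only rings: a number 2.00 log units lower from compound 3 to compound 4 (beyond the scatter) and a number 3.20 log units lower from compound 1 to compound 4 (beyond the scatter) are the two steps that show it. Until now, the only ring with a hetero atom at this position was the non-aromatic oxan-4-yl, and the aromatic pyridin-4-yl goes modestly further, with a number 0.40 log units lower from compound 2 to compound 4 (beyond the scatter) as the step between them. Group size alone also fails to order the numbers: pyridin-4-yl has more heavy atoms than cyclobutyl yet gives the lower number, whereas among the carbon-only rings the smaller cyclobutyl of compound 3 reads lower than the cyclohexyl of compound 1.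

The compounds shown leave open how much of the drop goes with the aromatic ring and how much with its nitrogen, and a phenyl group on the same carbonyl carbon would separate the two. Nothing available here gives an explanation for this result.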